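Benzamide ring substitution on the shared enone core

This account rests on a few compounds, and the source may have more. Where it says the series, first, only, none or still open, it means among the compounds named here.

Of the compounds shown here, three have been measured. Compound 1 `Cc1ccc(C(=O)Nc2ccc(C(=O)/C=C/c3nc(C)c(C)nc3C)cc2)cc1` gives 9990 nM in a functional assay on A549 cells (Homo sapiens) for antiproliferative activity, read by CCK-8 assay, with a stated time of 72 h; on this read-out lower numbers stand for stronger inhibition and higher numbers for weaker inhibition. Compound 2 `Cc1nc(C)c(/C=C/C(=O)c2ccc(NC(=O)c3ccccc3)cc2)nc1C` gives 7270 nM in the same assay, and compound 3 `COc1cc(C(=O)Nc2ccc(C(=O)/C=C/c3nc(C)c(C)nc3C)cc2)cc(OC)c1OC` gives 7350 nM. Compound 2 stands together with compounds 1 and 3: the three numbers all lie within the scatter of one another, so no order among them can be read. For the measured compounds named here, the one step that differs in a single place, a 1.4-fold lower number from compound 1 to compound 2 (0.14 log units; within the scatter), is likewise within the scatter. The values of compounds 2 and 3 show that a trimethoxy-bearing benzamide ring and an unsubstituted one land at the same number.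

Compound 4 `Cc1nc(C)c(/C=C/C(=O)c2ccc(NC(=O)c3ccc(F)cc3F)cc2)nc1C` is the next member. Its change from compound 2 is 2,4-difluorophenyl in place of phenyl on a carbonyl carbon. The step from compound 1 to compound 2 is the nearest comparison, a change on the same aromatic ring, and it did not move the number beyond the scatter; compounds 2 and 3 show the same picture. On this basis no step beyond the scatter is expected in this assay for compound 4, and the estimated step of a 1.2-fold lower number from compound 2 to compound 4 (0.08 log units; within the scatter) reflects that. Compound 4 is therefore expected near 6000 nM, within the range 2500 nM to 15000 nM.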

Compound 4, half-maximal inhibitory concentration: 2450 nM
Compound 4: the middle estimate sits 2.4-fold (0.39 log units) above what was measured; measured number outside the range, below it.
By their numbers in this assay, from the lowest: compound 4; then compounds 2, 3 and 1 (each within the scatter of the next).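

For the compounds shown here, the change from benzoyl to (2,4-difluorophenyl)carbonyl gives a 3.0-fold lower number from compound 2 to compound 4 (0.47 log units; beyond the scatter) in this assay and is the first single-place step to lie beyond the scatter. Replacing 4-methylphenyl with 2,4-difluorophenyl on the same carbonyl carbon gives a 4.1-fold lower number from compound 1 to compound 4 (0.61 log units; beyond the scatter) and points the same way, whereas the step between the 4-methylphenyl and phenyl groups stays within the scatter, so this position is not silent to every substitution. Both new steps are modest, and no measurement shown here bears on what lies behind them.

Compound 4 carries both fluorine atoms together, so the compounds shown leave open whether a single fluorine on this ring would give a step of similar size, and whether the same holds for chlorine, trifluoromethyl or nitrile. Going by these compounds, an amine or a carboxylic acid on this ring also remains open, as does whether the lower number seen with the 2,4-difluorophenyl group extends beyond this one cell line and read-out.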